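A Haloalkenyl Arm in Place of the Propargyl Group

This account rests on a few compounds, and the source may have more. Where it says the series, first, only, none or still open, it means among the compounds named here.

Compound 1 `OC1CCN(Cc2cccc(Br)c2)CC1N1CCN(c2ccccc2)CC1` carries a 3-bromophenyl group on a saturated chain carbon bound to an amine nitrogen in a ring, and in an assay on PC-12 cells for displacement of a labelled ligand from vesicular acetylcholine transporter (Homo sapiens) (on this read-out higher numbers stand for weaker inhibition and lower numbers for stronger inhibition), compound 1 gives 46 nM. Compound 2 `OC1CCN(Cc2ccc(Br)cc2)CC1N1CCN(c2ccccc2)CC1` bears 4-bromophenyl at that place. In this assay compound 2 reaches only a limit of the assay, > 100 nM, not a number. Compound 3 `C#CCN1CCC(O)C(N2CCN(c3ccccc3)CC2)C1` carries ethynyl there instead. For compound 3 too, this assay reports only a limit, > 100 nM, and not a number. Compound 3 thus stands at the limit of > 100 nM in this assay, at which 2 of the 3 values shown sit. The step of an at least 2.1-fold higher number from compound 1 to compound 3 (0.33 log units; beyond the scatter) is readable and at least modest, whereas the step that the two limits leave unreadable from compound 2 to compound 3 cannot be sized, since both ends are limits.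

Compound 4 `OC1CCN(C/C=C/I)CC1N1CCN(c2ccccc2)CC1` differs from compound 3 by 2-iodoethenyl in place of ethynyl on a saturated chain carbon bound to an amine nitrogen in a ring. Going by the values given here, no measured step describes this exchange; the only steps that touch the ethynyl arm come from compound 1 and compound 2, and of those only the one from compound 1 is readable. Compound 4 is therefore expected to remain near the limit, with the step that the limit leaves unreadable from compound 3 to compound 4 estimated to be small or unreadable. For compound 4 the estimate in this assay is 150 nM, within a range from 40 nM to 600 nM.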

Compound 4, half-maximal inhibitory concentration: > 100 nM
Compound 4 ended at the assay's limit (the forecaster's own chance of this, stated with the estimate: 55%); the middle value does not contradict the limit.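

The new arm adds one readable comparison at this place: in this assay, exchanging 3-bromophenyl for 2-iodoethenyl gives an at least 2.1-fold higher number from compound 1 to compound 4 (0.33 log units; beyond the scatter), the same kind of loss already seen with ethynyl. The steps to compound 4 from compound 2 and from compound 3 have limits at both ends and cannot be read, so nothing shows whether going from propargyl to 3-iodoprop-2-en-1-yl changes binding at all. What compound 4 does show is that a second small arm without a ring, this one carrying iodine, also fails to give a number, and compound 1 remains the only one of the four that does: the limit of > 100 nM in this assay, at which 3 of the 4 values shown sit.

Going by these compounds, how far compound 2, compound 3 and compound 4 lie past that limit stays open, and with it any order among 4-bromophenyl, ethynyl and 2-iodoethenyl at this place. Also open, on these data alone, is what the value of compound 1 depends on, whether the bromine or the aromatic ring, which a 3-chlorophenyl group, an unsubstituted phenyl group or a saturated chain such as butyl on the same carbon could begin to separate.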